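Moving the carboxyl group around the phenyl ring

The compounds below may be only part of what the source reports. "The series", "measured", "known", "first", "only" and "open" are said of these compounds alone.

Measured compounds:
compound 1 `Cc1c(OCCCCOc2ccc(C(=O)O)cc2Cl)ccc(C(=O)CC(C)C)c1O` – 99.5%
compound 2 `Cc1c(OCCCCOc2ccccc2C(=O)O)ccc(C(=O)CC(C)C)c1C` – 76.2%
compound 3 `Cc1cc(OCCCCOc2ccc(C(=O)CC(C)C)c(O)c2C)ccc1C(=O)O` – 93.3%

In an assay on HEK293 cells for positive allosteric modulation of metabotropic glutamate receptor 2 (Rattus norvegicus), read by thallium flux, with a stated time of 2.5 min (a lower number here means a smaller maximal response, a higher number a larger maximal response), compound 3 stands second highest of the three numbers; its nearest neighbour is compound 1, with a number 6.2 percentage points lower from compound 1 to compound 3 (within the scatter), and its furthest is compound 2, whose value lies beyond the scatter below it. Compound 4 `Cc1c(OCCCCOc2ccccc2C(=O)O)ccc(C(=O)CC(C)C)c1O` is not yet measured. It differs from compound 3 in one place: 2-carboxyphenyl in place of 4-carboxy-3-methylphenyl on an oxygen on a saturated carbon. For the measured compounds named here, no measured step covers this exact change. Going by the values given here, the only measured step, 4-carboxy-3-methylphenyl in place of 4-carboxy-2-chlorophenyl, stayed within the scatter. Compound 2 carries the same 2-carboxyphenyl group but on a different core, and its value is the lowest shown, so a moderate drop is expected, a number 9.3 percentage points lower from compound 3 to compound 4 (within the scatter), though a result within the scatter would not surprise. The estimate for compound 4 is 84%, with a range from 66% to 100%.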

Compound 4, largest response reached (reported as percent of maximum), in percent of the reference or control that the assay uses: 92.4%
For compound 4 the middle estimate is 8.4 percentage points below the measured one; measured number inside the range.
By their numbers in this assay, from the lowest: compound 2; then compounds 4, 3 and 1 (each within the scatter of the next).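

In this assay, the 2-carboxyphenyl group on the shared core of compound 4 gives no response that can be told apart from the other two rings: the step is a number 0.9 percentage points lower from compound 3 to compound 4 (within the scatter), and the comparison with the chlorinated ring is a number 7.1 percentage points lower from compound 1 to compound 4 (within the scatter). For the compounds shown here, the low value of compound 2 is therefore not tied to the 2-carboxyphenyl group alone, since hydroxy in place of methyl on an aromatic carbon gives a number 16.2 percentage points higher from compound 2 to compound 4 (beyond the scatter), the only step here beyond the scatter. Nothing available explains why this single swap matters.

From the compounds shown here alone, whether the hydroxy step would be as large with 4-carboxy-3-methylphenyl or 4-carboxy-2-chlorophenyl in place of 2-carboxyphenyl remains open. So does the response with a methoxy group or an amine in place of that hydroxy, or with a tetrazole in place of the carboxylic acid.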